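This account rests on a few compounds, and the source may have more. Where it says the series, first, only, none or still open, it means among the compounds named here.

The measured compounds, each with its reading in a functional assay on HL-60 cells (Homo sapiens) for antiproliferative activity, read by XTT assay, with a stated time of 72 h; a higher number here means a weaker inhibitor, a lower number a stronger inhibitor:

Compound 1, `Cc1nc(N)c2c(-c3cccs3)cn([C@@H]3O[C@H](CO)[C@@H](O)[C@H]3O)c2n1`, gives > 20000 nM, which is a limit of the assay and not a number.
Compound 2, `COc1nc(N)nc2c1c(-c1cccs1)cn2[C@@H]1O[C@H](CO)[C@@H](O)[C@H]1O`, gives > 20000 nM, again a limit rather than a number.
Compound 3, `Nc1nc(N)c2c(-c3cccs3)cn([C@@H]3O[C@H](CO)[C@@H](O)[C@H]3O)c2n1`, gives > 20000 nM, also a limit.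

Compound 3 therefore stands at the limit in this assay, and the two values beside it are limits as well, so no ranking among the three can be read. The step that the two limits leave unreadable from compound 1 to compound 3 and the step that the two limits leave unreadable from compound 2 to compound 3 are both left unreadable, since each end sits at the limit; this follows from the limit of > 20000 nM in this assay, at which 3 of the 3 values shown sit.

The next compound, compound 4, `Nc1nc(N)c2c(-c3ccco3)cn([C@@H]3O[C@H](CO)[C@@H](O)[C@H]3O)c2n1`, differs from compound 3 in one place: furan-2-yl in place of thiophen-2-yl on an aromatic carbon. Going by the values given here, none of the measured steps touches this group, so none of them bears on the change, and their sizes give no guide. What the data do show is that every reading so far, including that of compound 3, sits at the limit, and the change is a swap of one five-membered aromatic ring for another of the same size and count.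

Compound 4 is therefore expected to remain at or near the limit, with an estimated value of 30000 nM, between 8000 nM and 150000 nM, which would mean an expected step that the limit leaves unreadable from compound 3 to compound 4.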

Compound 4, half-maximal inhibitory concentration: > 20000 nM
Compound 4: only a limit was reported (the forecaster's own chance of this, stated with the estimate: 85%); the middle value is on the limit's open side.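

In this assay compound 4 gives > 20000 nM, which is a limit of the assay and not a number. No step can be read from compound 3 to compound 4, as both sit at a limit: the limit of > 20000 nM in this assay, at which 4 of the 4 values shown sit.

The compounds shown leave open how these four rank against one another and whether any change to the shared core would give a readable value.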